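Sulfonamide benzoxazoles: a ring-position swap and a methyl for methoxy

The source may report more compounds than this note shows. Statements on the series, on what has been measured and on what is new or still open speak of the compounds shown alone.

Measured compounds:
compound 1 `Cc1ccccc1S(=O)(=O)Nc1ccc2oc(-c3ccccc3)nc2c1` – > 100000 nM (a limit)
compound 2 `COc1cccc(S(=O)(=O)Nc2ccc3oc(-c4ccccc4)nc3c2)c1` – > 100000 nM (a limit)
compound 3 `COc1cccc(S(=O)(=O)Nc2ccc(-c3nc4ccccc4o3)cc2)c1` – 80000 nM

In an assay on cells for inhibition of HSP60/HSP10 (Homo sapiens), with a stated time of 60 min (a higher number here means a weaker inhibitor, a lower number a stronger inhibitor), compound 1 gives > 100000 nM, which is a limit of the assay and not a number. In this assay compound 2 likewise gives > 100000 nM, again a limit. Among the measured compounds shown here, compound 3 is the only one with a number: in this assay it gives 80000 nM. Compound 2 and compound 3 are built from the same atoms joined differently; the difference between the two cores is not broken down here. For the measured compounds named here, the one shared change is 2-methylphenyl in place of 3-methoxyphenyl on a sulfonyl sulfur, measured as a step that the two limits leave unreadable from compound 2 to compound 1. It leaves no readable step, which follows from the limit of > 100000 nM in this assay, at which 2 of the 3 values shown sit.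

Compound 4 `Cc1ccccc1S(=O)(=O)Nc1ccc(-c2nc3ccccc3o2)cc1` is not yet measured. Its change from compound 3 is the same one, (2-methylphenyl in place of 3-methoxyphenyl on a sulfonyl sulfur), with the same place. The earlier step from the first pair stands unreadable. Beside it, the expected step from compound 3 to compound 4 is a 1.5-fold higher number from compound 3 to compound 4 (0.18 log units; within the scatter), resting only on compound 3 at 80000 nM, so a value close to compound 3 is expected. Compound 4 is therefore estimated at 120000 nM, with a range from 50000 nM to 300000 nM.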

Compound 4, half-maximal inhibitory concentration: 85000 nM
Estimate against measurement, compound 4: 1.4-fold (0.15 log units) above, and the stated range covers the measured number.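

In this assay, 2-methylphenyl in place of 3-methoxyphenyl on a sulfonyl sulfur gives a 1.1-fold higher number from compound 3 to compound 4 (0.03 log units; within the scatter), so on this core the two groups cannot be told apart. The step from compound 2 to compound 1 cannot be read, so nothing can be said about whether the result carries over to the other core: the limit of > 100000 nM in this assay, at which 2 of the 4 values shown sit. What stands is one readable pair on one core, and it does not show that the swap is neutral on the core of compound 1.

Open, going by these compounds, is whether any group on the sulfonyl sulfur gives a step beyond the scatter on either core, as only these two aryl groups appear there. On these data alone, how an amine, a carboxylic acid or a longer chain in place of either ring would read in this assay also stays open, on both cores.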